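Swapping One Propoxypyrimidine Ring for Its Isomer

This account rests on a few compounds, and the source may have more. Where it says the series, first, only, none or still open, it means among the compounds named here.

Compound 3 `CCCOc1ccnc(N2CCN(c3nc(N)c4cc(OC)c(OC)cc4n3)CC2)n1` is measured in an assay on brain for binding affinity to Adrenergic receptor alpha-1 (Rattus norvegicus) (a higher number here means a weaker inhibitor, a lower number a stronger inhibitor), at 0.32 nM. It stands second highest of three numbers: compound 1 `COc1cc2nc(N3CCN(c4cccnn4)CC3)nc(N)c2cc1OC` gives 0.4 nM, and compound 2 `COc1cc2nc(N3CCN(c4cnccn4)CC3)nc(N)c2cc1OC` gives 0.18 nM; the steps of a 1.3-fold lower number from compound 1 to compound 3 (0.10 log units; within the scatter) and a 1.8-fold higher number from compound 2 to compound 3 (0.25 log units; within the scatter) both stay within the scatter. Compound 4 `CCCOc1cc(N2CCN(c3nc(N)c4cc(OC)c(OC)cc4n3)CC2)ncn1` differs from compound 3 in one place: 6-propoxypyrimidin-4-yl in place of 4-propoxypyrimidin-2-yl on an amine nitrogen in a ring. Within the data shown here, no measured step exchanges one propoxypyrimidine for another, so the only guides are the three ring exchanges already seen, a 2.2-fold lower number from compound 1 to compound 2 (0.35 log units; beyond the scatter), a 1.3-fold lower number from compound 1 to compound 3 (0.10 log units; within the scatter) and a 1.8-fold higher number from compound 2 to compound 3 (0.25 log units; within the scatter), of which only the first passes the scatter. The expected step is therefore small, a 1.3-fold higher number from compound 3 to compound 4 (0.10 log units; within the scatter), with no firm direction. Compound 4 is estimated at 0.4 nM, with a range from 0.15 nM to 1.2 nM.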

Compound 4, inhibition constant: 0.36 nM
Beside the measured number, compound 4's estimate is 1.1-fold (0.05 log units) above it, within the range that was stated.
By their numbers in this assay, from the lowest: compounds 2, 3, 4 and 1 (each within the scatter of the next, the first and the last beyond it).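

Exchanging 4-propoxypyrimidin-2-yl for its isomer 6-propoxypyrimidin-4-yl on the ring nitrogen gives a 1.1-fold higher number from compound 3 to compound 4 (0.05 log units; within the scatter) in this assay, so at this position, joining the same atoms differently leaves the reading within the scatter. The new ring also stays within the scatter of the pyrazin-2-yl and pyridazin-3-yl compounds, with a 2.0-fold higher number from compound 2 to compound 4 (0.30 log units; within the scatter) and a 1.1-fold lower number from compound 1 to compound 4 (0.05 log units; within the scatter). No measurement available here explains why the two isomers read alike. Going by these compounds, whether the propoxy chain itself matters remains open, and an ethoxy chain, a butoxy chain or an amine on the same pyrimidine could test how far this insensitivity extends.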